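Expected effect of adding bromo to compound 2

The source may hold more compounds than are shown below. What is called first, only, known or untested is meant among the compounds shown, and "the series" means these compounds.

Compound 1 `COc1ccc(O)c(/C=C/C(=O)c2ccc(Cl)cc2)c1` and compound 2 `COc1cc(Br)cc2c1OC(N)=C(C#N)C2CC(=O)c1ccccc1` were both examined in a functional assay on MCF7 cells (Homo sapiens) for antiproliferative activity, read by sulforhodamine B assay, with a stated time of 72 h, tested at 10 uM; on this read-out lower numbers stand for a stronger effect and higher numbers for a weaker effect at the one concentration tested. In this assay compound 1 gives 86.9%, while compound 2 gives 99.1%, the highest of the two numbers and beyond the scatter from compound 1. Compound 3 `COc1cc(Br)cc2c1OC(N)=C(C#N)C2CC(=O)c1ccc(Br)cc1` differs from compound 2 by bromo in place of hydrogen on an aromatic carbon. Within the data shown here, no step between measured compounds is available for this change, so the step of a number 4.1 percentage points lower from compound 2 to compound 3 (within the scatter) is expected to be small, with no shift beyond the scatter in either direction. Compound 3 is therefore estimated at 95%, within a range from 78% to 106%.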

Compound 3, a percentage reported as activity, at one concentration (the size of the read-out at that concentration, not a potency): 39.7%
The estimate for compound 3 lay 55.3 percentage points above the measured number; measured number below the stated range.
By their numbers in this assay, from the lowest: compound 3; then compound 1; then compound 2.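

In this assay the change from phenyl to 4-bromophenyl gives a large step (a number 59.4 percentage points lower from compound 2 to compound 3 (beyond the scatter)), so this place on the aromatic ring, para to a large group, responds strongly to a single bromo in place of hydrogen. Compound 1 and compound 2 differ in more than one place and could not show this. Nothing measured here gives a reason for the step.

From the compounds shown here alone, whether chloro, methoxy, an amine or a carboxylic acid at this place would give a step of similar size remains open. So does whether bromo here would act alike in compounds lacking the bromo on the shared core.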